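The compounds below may be only part of what the source reports. "The series", "measured", "known", "first", "only" and "open" are said of these compounds alone.

Compound 1 `CC(C)c1ccc(-c2cc(=O)c3cc(C(=O)O)ccc3o2)cc1`: 19%
Compound 2 `COc1ccc(-c2cc(=O)c3cc(C(=O)O)ccc3o2)cc1`: 13%

In a functional assay on the whole organism (stomach) for inhibition, with Rattus norvegicus as the target, at a dose of 80 mg/kg (on this read-out lower numbers stand for less inhibition and higher numbers for more inhibition at the one dose given (going by the name of the read-out)), compound 2 gives 13%, at the low end of the two numbers shown, while compound 1 gives 19%; the step of a number 6 percentage points lower from compound 1 to compound 2 (within the scatter) lies within the scatter. Compound 3 `O=C(O)c1ccc2oc(-c3ccc(F)cc3)cc(=O)c2c1` differs from compound 2 by fluoro in place of methoxy on an aromatic carbon. Within the data shown here, no measured step exchanges methoxy for fluoro. Among the measured compounds shown here, the one step on this aromatic carbon, a number 6 percentage points lower from compound 1 to compound 2 (within the scatter), stayed within the scatter, so no step beyond the scatter is expected here. Compound 3 is therefore estimated at 15%, within a range from 5% to 28%. This estimate means an expected step of a number 2 percentage points higher from compound 2 to compound 3 (within the scatter).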

Compound 3, a percentage reported as inhibition, in the whole organism at one dose (the size of the read-out at that dose, not a potency): 21%
For compound 3 the middle estimate is 6 percentage points below the measured one, within the range that was stated.
By their numbers in this assay, from the lowest: compounds 2, 1 and 3 (each within the scatter of the next).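

Fluoro on this aromatic carbon, para to a large group, adds a third group to the comparison in this assay: the read-out shows a number 8 percentage points higher from compound 2 to compound 3 (within the scatter) and a number 2 percentage points higher from compound 1 to compound 3 (within the scatter). Replacing methoxy or isopropyl with fluoro therefore produces no step beyond the scatter, so this read-out at this one dose separates none of the three groups. No evidence bears on these steps.

As far as these compounds go, whether an amine or a longer chain on this carbon would give a step beyond the scatter in this assay stays open.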